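The source may hold more compounds than are shown below. What is called first, only, known or untested is meant among the compounds shown, and "the series" means these compounds.

Compound 2 `COC(=O)[C@H](CCSC)NC(=O)c1ccc(NCc2cncn2Cc2ccc([N+](=O)[O-])cc2)cc1-c1ccccc1` in a functional assay on NIH3T3 cells (Mus musculus) (on this read-out lower numbers stand for an effect already at smaller amounts and higher numbers for an effect only at larger amounts of compound), gives only a limit, > 10 uM. Compound 1 `CSCC[C@H](NC(=O)c1ccc(NCc2cncn2Cc2cccc(Cl)c2)cc1-c1ccccc1)C(=O)O` likewise reaches only a limit in this assay, > 10 uM. Both known values thus sit at the limit of > 10 uM in this assay, at which 2 of the 2 values shown sit. The change to compound 3 `COC(=O)[C@H](CCSC)NC(=O)c1ccc(NCc2cncn2Cc2cccc(Cl)c2)cc1-c1ccccc1` is 3-chlorophenyl in place of 4-nitrophenyl on a saturated chain carbon bound to an aromatic nitrogen. Among the compounds with values here, no measured step covers this change, and with both known values at a limit no direction can be read from them. A step that the limit leaves unreadable from compound 2 to compound 3 is expected, none beyond the scatter. Compound 3 is expected to give 15 uM in this assay, within a range from 4 uM to 60 uM, most probably again reported only as a limit.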

Compound 3, concentration for half-maximal effect: > 10 uM
Compound 3 gave a limit, no number; the forecaster's own chance of this, stated with the estimate: 75%; the middle value does not contradict the limit.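

No step can be read between compound 3 and compound 2, or between compound 3 and compound 1, in this assay: the limit of > 10 uM in this assay, at which 3 of the 3 values shown sit. Whether either change alters the effect, and at what concentration any of these compounds acts, stays open.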